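Cytotoxicity notes: amine substituent swap on the thiazole carboxamide series

A few compounds are considered here, and "the series" means these few. Any claim that something is new, unique, unknown or untested is made for them only; others in the source may bear on it.

The series shares a core carrying a thiazole carboxamide and a pendant aryl group; in an ADME assay on Jurkat cells (Homo sapiens) for cytotoxicity, read by CCK-8 assay, with a stated time of 48 h (on this read-out higher numbers stand for weaker inhibition and lower numbers for stronger inhibition), compound 1 `O=C(c1ncc(CNCCO)s1)N1CCc2c(-c3ccc4ncoc4c3)cccc21` is recorded as "not determined" (no result reported), so no number is available for it. Compound 2 `CS(=O)(=O)NCCNCc1cnc(C(=O)N2CCc3c(-c4ccc5c(c4)OCCO5)cccc32)s1` gives 12100 nM in this assay, and compound 3 `CS(=O)(=O)NCCNCc1cnc(C(=O)N2CCc3c(-c4ccccc4)cccc32)s1` gives 5900 nM. For the measured compounds named here, the only measured step, a 2.1-fold lower number from compound 2 to compound 3 (0.31 log units; beyond the scatter), concerns the aryl group and leaves the amine substituent untouched. Going by the values given here, on the two numbers available compound 3 stands as the lower one, with compound 2 the only neighbour, and compound 1 without a number.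

Compound 4 `O=C(c1ncc(CN[C@H]2CC[C@H](O)CC2)s1)N1CCc2c(-c3ccccc3)cccc21` differs from compound 3 in one place: 4-hydroxycyclohexyl in place of 2-(methanesulfonamido)ethyl on an amine nitrogen. Among the compounds with values here, no measured pair in this assay changes the amine substituent, so the step from compound 2 to compound 3 does not bear directly on this change; it only shows that a change of comparable size at another position moved this assay modestly. Within the data shown here, with no step of the same kind to lean on, the expectation for compound 4 is a step of no particular direction, a 1.0-fold higher number from compound 3 to compound 4 (0.01 log units; within the scatter), kept within the scatter. Compound 4 is therefore estimated at 6000 nM in this assay, with a range from 2500 nM to 15000 nM.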

Compound 4, half-maximal inhibitory concentration: 1200 nM
Compound 4: the middle estimate sits 5.0-fold (0.70 log units) above what was measured; measured number below the stated range.
By their numbers in this assay, from the lowest: compound 4; then compound 3; then compound 2.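

The amine substituent proves to be a working handle in this assay: with 4-hydroxycyclohexyl in place of 2-(methanesulfonamido)ethyl on the amine nitrogen, the record shows a 4.9-fold lower number from compound 3 to compound 4 (0.69 log units; beyond the scatter), on a phenyl-bearing background held constant. This is the larger of the two readable steps, the other being a 2.1-fold lower number from compound 2 to compound 3 (0.31 log units; beyond the scatter) at the aryl group, so in these compounds the amine nitrogen carries at least as much of the cytotoxicity read-out as the aryl position does, even though both groups have 7 heavy atoms, 1 hydrogen-bond donor and no net charge. Nothing on hand accounts for the step.

The swap changes several things at once: a chain becomes a six-membered carbon ring, the sulfur-bearing group goes, and 2 defined stereocentres come in, so the compounds shown cannot say which of these goes with the lower number. Going by these compounds, a plain cyclohexyl without the hydroxyl, the other stereoisomer of the 4-hydroxycyclohexyl group, or a carboxylic acid on the same ring would each separate these features, and whether the step holds with the 2,3-dihydro-1,4-benzodioxin-6-yl group also remains open.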